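The source may report more compounds than this note shows. Statements on the series, on what has been measured and on what is new or still open speak of the compounds shown alone.

Compound 2 `COc1ccc(-c2cc3ccccc3nc2/C=C/C(=O)c2ccc(N)cc2)cc1` carries the highest number of the two measured here: in a functional assay on MDA-MB-231 cells (Homo sapiens) for antiproliferative activity, read by XTT assay, with a stated time of 72 h (a higher number here means a weaker inhibitor, a lower number a stronger inhibitor), compound 2 gives 7510 nM. Its closest neighbour is compound 1 `COc1ccc(-c2cc3ccccc3nc2/C=C/C(=O)c2ccccc2)cc1`, which in this assay gives 860 nM. Within the data shown here, the single measured step, an 8.7-fold higher number from compound 1 to compound 2 (0.94 log units; beyond the scatter), shows that adding an amino group to the aromatic ring on the carbonyl weakened the compound beyond the scatter. Compound 3 `COc1ccc(-c2cc3ccccc3nc2/C=C/C(=O)c2ccc[nH]2)cc1` has not been measured. Compared with compound 2 it differs by 1H-pyrrol-2-yl in place of 4-aminophenyl on a carbonyl carbon. Among the measured compounds shown here, no measured step shows what a 1H-pyrrol-2-yl group does in this place, so the only bearing comes from the step to compound 2, which attaches the loss of potency to the 4-aminophenyl group that now departs. The step of a 3.0-fold lower number from compound 2 to compound 3 (0.48 log units; beyond the scatter) is therefore expected to run toward a lower number, though with wide uncertainty. Compound 3 is estimated at 2500 nM, within a range from 600 nM to 10000 nM.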

Compound 3, half-maximal inhibitory concentration: > 10000 nM
Compound 3 ended at the assay's limit; the forecaster's own chance of this, stated with the estimate: 5%; middle value at least 4.0-fold (0.60 log units) from the limit.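

For compound 3 the result in this assay is a limit and not a number: the limit of > 10000 nM in this assay, at which 1 of the 3 values shown sits. Measured against the phenyl group, the 1H-pyrrol-2-yl group on this carbonyl carbon gives an at least 11-fold higher number from compound 1 to compound 3 (1.06 log units; beyond the scatter), so this second replacement also loses potency, and it does so with a smaller ring rather than with an added amino group. Against the 4-aminophenyl group the reading is only an at least 1.3-fold higher number from compound 2 to compound 3 (0.12 log units; that floor lies within the scatter), a floor that lies within the scatter, so the order of those two cannot be settled, and compound 1 stays the strongest of the three.

The compounds shown leave open how far compound 3 really lies past the limit. They also leave open whether a furan ring or a pyridine ring on this carbonyl carbon would hold the potency of the phenyl group.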